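A Side Chain Change on a Shared Core

The source may report more compounds than this note shows. Statements on the series, on what has been measured and on what is new or still open speak of the compounds shown alone.

Compound 1 `O=C1c2c[n+]([O-])c3ccccc3c2C(=O)c2c1c1ccccc1n2Cc1cn(CC(O)CO)nn1`: 440 nM
Compound 2 `O=C1c2c[n+]([O-])c3ccccc3c2C(=O)c2c1c1ccccc1n2CCN1CCCC1`: 430 nM

Both compounds were tested in a functional assay on A-375 cells (Homo sapiens) for cytotoxicity, read by MTT assay, with a stated time of 72 h; a lower number here means a stronger inhibitor, a higher number a weaker inhibitor. Compound 2 stands level with compound 1, as the two values lie within the scatter of each other. Compound 3 `CN1CCN(CCCn2c3c(c4ccccc42)C(=O)c2c[n+]([O-])c4ccccc4c2C3=O)CC1` has not yet been measured. It differs from compound 2 as follows: (4-methylpiperazin-1-yl)methyl in place of pyrrolidin-1-yl on a saturated chain carbon, two bonds along the chain from an aromatic nitrogen. In words, (4-methylpiperazin-1-yl)methyl takes the place of pyrrolidin-1-yl on a saturated chain carbon, two bonds along the chain from an aromatic nitrogen.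

Going by the values given here, only one measured step bears on this change. That step, a 1.0-fold lower number from compound 1 to compound 2 (0.01 log units; within the scatter), exchanged one group for a very different one on a saturated chain carbon bound to an aromatic nitrogen, and the number in this assay stayed within the scatter. Among the compounds with values here, one step is thin evidence, and no measured compound carries the entering group. Even so, no step beyond the scatter is expected in this assay, in either direction. The expected step is a 1.1-fold lower number from compound 2 to compound 3 (0.03 log units; within the scatter). For compound 3 the estimate is 400 nM, with an expected range of 170 nM to 950 nM.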

Compound 3, half-maximal inhibitory concentration: 470 nM
Compound 3: middle estimate off by 1.2-fold (0.07 log units), on the low side, within the range that was stated.
By their numbers in this assay, from the lowest: compounds 2, 1 and 3 (each within the scatter of the next).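

In this assay, (4-methylpiperazin-1-yl)methyl in place of pyrrolidin-1-yl, on a saturated chain carbon, two bonds along the chain from an aromatic nitrogen, gives a 1.1-fold higher number from compound 2 to compound 3 (0.04 log units; within the scatter), so the number holds level when a five-membered non-aromatic ring with 1 hetero atom gives way to a six-membered non-aromatic ring with 2 hetero atoms. The wider exchange of 1-(2,3-dihydroxypropyl)-1H-1,2,3-triazol-4-yl for 2-(4-methylpiperazin-1-yl)ethyl, on a saturated chain carbon bound to an aromatic nitrogen, gives a 1.1-fold higher number from compound 1 to compound 3 (0.03 log units; within the scatter), which means that all three side chains on the shared core now stand level and the earlier single step no longer stands alone. Nothing measured in this account bears on why these side chains leave the number level.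

As far as these compounds go, whether a carboxylic acid or a primary amine at the end of the chain, or a chain longer than 3-(4-methylpiperazin-1-yl)propyl, would move the number beyond the scatter remains open. All three compounds also keep the shared core unchanged, so the compounds shown say nothing about what a change in the core itself would do.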